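Carboxy for Vinyl on a Xanthine Side Chain

The compounds below may be only part of what the source reports. "The series", "measured", "known", "first", "only" and "open" are said of these compounds alone.

Measured compounds:
Compound 1, `C=CCn1c(=O)c2[nH]cnc2n(CCC)c1=O`: 1600 nM
Compound 2, `CCCn1c(=O)n(CC(=O)O)c(=O)c2[nH]cnc21`: 41000 nM
Compound 3, `C=CCCn1cnc2c1c(=O)n(C)c(=O)n2CCC`: 16800 nM

In a functional assay (trachea) with Cavia porcellus as the target (a higher number here means that more compound is needed for the effect, a lower number that less compound is needed), compound 1 gives 1600 nM, the lowest number of the three. Compound 2 gives 41000 nM, and compound 3 gives 16800 nM, which lies second highest of the three numbers. Going by the values given here, the single change between the first two, (carboxy in place of vinyl on a saturated chain carbon bound to an aromatic nitrogen), produced a 26-fold higher number from compound 1 to compound 2 (1.41 log units; beyond the scatter).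

Compound 4, `CCCn1c(=O)n(C)c(=O)c2c1ncn2CCC(=O)O`, has not yet been tested in this assay. It stands to compound 3 as compound 2 stands to compound 1: carboxy in place of vinyl on a saturated chain carbon, two bonds along the chain from an aromatic nitrogen. The change itself is the same, but its place is not word for word the same: in compound 2 the carboxy sits on a saturated chain carbon bound to an aromatic nitrogen, whereas in compound 4 it sits on a saturated chain carbon two bonds along the chain from an aromatic nitrogen, so this is the same kind of change rather than the same change. The difference between the core of compound 1 and the core of compound 3 is not broken down here.

Because the earlier carboxy for vinyl exchange gave a 26-fold higher number from compound 1 to compound 2 (1.41 log units; beyond the scatter), the step from compound 3 to compound 4 is expected to run in the same direction, though the different place makes its size less certain, and the expected step is a 7.7-fold higher number from compound 3 to compound 4 (0.89 log units; beyond the scatter). Compound 4 is therefore estimated to give 130000 nM in this assay, with a likely range from 30000 nM to 500000 nM.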

Compound 4, half-maximal effective concentration: > 100000 nM
Compound 4: no number, only a limit; the forecaster's own chance of this, stated with the estimate: 30%; the middle value lies beyond the limit too.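

In this assay compound 4 gives > 100000 nM, which is a limit of the assay and not a number. On the core of compound 3, carboxy in place of vinyl gives an at least 5.9-fold higher number from compound 3 to compound 4 (0.77 log units; beyond the scatter), so the step runs in the same direction as the one on the core of compound 1, and in this single pair of cores the direction of the change carries over. It does not show that the size carries over, and the comparison also rests on just two examples in which the carboxy sits in different places on the side chain, so no general rule for the series follows: the same change on two cores in this assay, a 26-fold higher number (1.41 log units; beyond the scatter) from compound 1 to compound 2 and an at least 5.9-fold higher number (0.77 log units; beyond the scatter) from compound 3 to compound 4; the limit leaves it open whether they differ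

The compounds shown leave open whether core or place matters more, since neither 2-carboxyethyl on the core of compound 1 nor carboxymethyl on the core of compound 3 is among them. They also leave open whether a methyl ester, a primary amide or a longer chain ending in a carboxylic acid would behave as the carboxy does, and how far the number of compound 4 lies past what can be read: the limit of > 100000 nM in this assay, at which 1 of the 4 values shown sits.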